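The compounds below may be only part of what the source reports. "The series", "measured", "known", "first", "only" and "open" are said of these compounds alone.

For the measured compounds named here, compound 3, whose structure is `NS(=O)(=O)c1ccc(Nc2nc3nc(=O)[nH]c(-c4ccccc4)c3s2)cc1`, stands at the low end of the numbers measured so far: in a functional assay on Caco-2 cells (Homo sapiens) for cytotoxicity, read by MTT assay, with a stated time of 24 h (on this read-out lower numbers stand for stronger inhibition and higher numbers for weaker inhibition), compound 3 gives 334 nM. The two other measured compounds sit on a different core. In this assay compound 2, `NS(=O)(=O)c1ccc(NC2=NC(=O)/C(=C/c3ccc(Cl)cc3)S2)cc1`, gives 667 nM, which lies within the scatter of compound 3, while compound 1, `COc1ccc(/C=C2\SC(Nc3ccc(S(N)(=O)=O)cc3)=NC2=O)cc1`, gives 1330 nM, a gap beyond the scatter from compound 3.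

Compound 4, `COc1ccc(-c2[nH]c(=O)nc3nc(Nc4ccc(S(N)(=O)=O)cc4)sc23)cc1`, keeps the core of compound 3 and differs from it in one place: methoxy in place of hydrogen on an aromatic carbon. Going by the values given here, the only measured step between neighbours, a 2.0-fold lower number from compound 1 to compound 2 (0.30 log units; within the scatter), exchanges a methoxy for a chloro on an aromatic carbon and is within the scatter. It does not compare methoxy with hydrogen, and it sits on the other core, so it bears on the present change only loosely; it does suggest that a small substituent on that ring shifts this assay little. Among the compounds with values here, no measured pair shows what adding a methoxy to a bare phenyl does.

On that basis the step from compound 3 to compound 4 is expected to be small, a 1.0-fold higher number from compound 3 to compound 4 (0.02 log units; within the scatter), with no clear direction. For compound 4 the expected value in this assay is 350 nM, within a range from 150 nM to 800 nM.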

Compound 4, half-maximal inhibitory concentration: 667 nM
The estimate for compound 4 lay 1.9-fold (0.28 log units) below the measured number; low and high end bracket the measured number.
By their numbers in this assay, from the lowest: compounds 3, 2, 4 and 1 (each within the scatter of the next, the first and the last beyond it).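

For the compounds shown here, on the core of compound 3, the exchange of phenyl for 4-methoxyphenyl gives a 2.0-fold higher number from compound 3 to compound 4 (0.30 log units; within the scatter) in this assay and so provides the first direct comparison of methoxy with hydrogen, here on an aromatic carbon para to a large group. A methoxy can therefore be placed on this bare phenyl without a shift that stands clear of the usual variation between repeated measurements, so this single pair gives no firm sign that the group helps or harms in this cytotoxicity read-out. The earlier step, a 2.0-fold lower number from compound 1 to compound 2 (0.30 log units; within the scatter), also stayed within the scatter, so both single-place exchanges shown on this ring are small, though they sit on different cores and involve different groups (no measured property is available to explain the result).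

The compounds shown leave open whether a chloro on the shared core would behave as it does on the core of compound 1. They also leave open whether an amine, a carboxylic acid or a longer chain such as butoxy in the same place would produce a step beyond the scatter.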